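Sulfonyl aryl variation on the shared core

The source may report more compounds than this note shows. Statements on the series, on what has been measured and on what is new or still open speak of the compounds shown alone.

Three measured compounds share one core and differ only at the group on the sulfonyl sulfur. Compound 1 `CC(C)n1nc(S(=O)(=O)c2cccc3ccccc23)c2cc(N3CCN(C)CC3)ccc21` gives 98% in a functional assay on HeLa cells for antagonist activity at 5-hydroxytryptamine receptor 6 (Homo sapiens); a higher number here means a larger maximal response, a lower number a smaller maximal response; compound 2 `COc1cccc(S(=O)(=O)c2n[nH]c3ccc(N4CCN(C)CC4)cc23)c1` gives 100%; compound 3 `CN1CCN(c2ccc3[nH]nc(S(=O)(=O)c4ccc(F)cc4)c3c2)CC1` gives 98%. The single one-point step, a number 2 percentage points lower from compound 2 to compound 3 (within the scatter), stays within the scatter, and compound 3 sits level with compound 1 at the digits shown, with compound 2 within the scatter of both. Compound 4 `CN1CCN(c2ccc3[nH]nc(S(=O)(=O)c4cccs4)c3c2)CC1` carries thiophen-2-yl in place of 4-fluorophenyl on a sulfonyl sulfur. Among the measured compounds shown here, no measured step covers this exact change; the one step available at the sulfonyl sulfur was flat, and every aryl group so far leaves the maximal response essentially unchanged. The step is therefore expected to be flat: no change at the digits printed from compound 3 to compound 4 (within the scatter). Compound 4 is estimated at 98%, range 90% to 104%.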

Compound 4, largest response reached (reported as Imax), in percent of the reference or control that the assay uses: 96%
The estimate for compound 4 lay 2 percentage points above the measured number; the measured number falls inside the stated range.
By their numbers in this assay, from the lowest: compounds 4, 1, 3 and 2 (each within the scatter of the next).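

Swapping to thiophen-2-yl puts a five-membered aromatic ring with 1 hetero atom on the sulfonyl sulfur, and the change stays flat in this assay, with a number 2 percentage points lower from compound 3 to compound 4 (within the scatter) and a number 4 percentage points lower from compound 2 to compound 4 (within the scatter) on the same position. Flatness at this position therefore now extends beyond six-membered aromatic rings of carbon only. Nothing available accounts for this lack of change.

Still open, on these data alone, is whether a non-aromatic group on the sulfonyl sulfur, such as methyl or cyclohexyl, would shift the maximal response. The same holds for an aryl ring carrying an amine or a carboxylic acid.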